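Methoxy in Place of Hydroxymethyl on Compound 1

This account rests on a few compounds, and the source may have more. Where it says the series, first, only, none or still open, it means among the compounds named here.

Measured in a toxicity assay on EA.hy 926 cells (Homo sapiens) for cytotoxicity, read by MTT assay, with a stated time of 48 h; a higher number here means a weaker inhibitor, a lower number a stronger inhibitor:
Compound 1 `O=C(/C=C(/C=C/c1ccc(O)cc1)NCCCO)/C=C/c1ccc(O)cc1`: 57300 nM
Compound 2 `COc1cc(/C=C/C(=O)/C=C(/C=C/c2ccc(O)c(OC)c2)NCCCO)ccc1O`: > 100000 nM, a limit of the assay and not a number

Within the data shown here, compound 1 holds the only true number so far, which makes it the reference point for anything new. Compound 2 offers only a limit. The next compound, compound 3 `COCCNC(=C\C(=O)/C=C/c1ccc(O)cc1)/C=C/c1ccc(O)cc1`, has not yet been measured. It has the same atoms as compound 1, joined differently: methoxy in place of hydroxymethyl on a saturated chain carbon, two bonds along the chain from an amine nitrogen. Put simply, methoxy stands in place of hydroxymethyl on a saturated chain carbon, two bonds along the chain from an amine nitrogen. Among the measured compounds shown here, no measured pair here shows what this swap does, so the expectation rests on compound 1 alone, with its 57300 nM. The change is small on paper, and no step beyond the usual scatter is expected in this assay, nor any firm direction. The expected change is a 1.0-fold higher number from compound 1 to compound 3 (0.02 log units; within the scatter). For compound 3 the estimate is 60000 nM, with an expected range from 28000 nM to 100000 nM.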

Compound 3, half-maximal inhibitory concentration: 45100 nM
Compound 3: the middle estimate sits 1.3-fold (0.12 log units) above what was measured; measured number inside the range.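

In this assay, methoxy in place of hydroxymethyl on a saturated chain carbon, two bonds along the chain from an amine nitrogen, gives a 1.3-fold lower number from compound 1 to compound 3 (0.10 log units; within the scatter), so this swap cannot be told apart from repeat-to-repeat variation. It is the first step shown at this position, and it takes the group's hydrogen-bond donor count from 1 to 0 while its acceptor count stays at 1, with no change in the read-out that can be separated from the scatter. Compound 2 adds nothing to this step, as it differs from the other compounds in more than one place and its value is a limit of the assay and not a number: the limit of > 100000 nM in this assay, at which 1 of the 3 values shown sits.

From the compounds shown here alone, a single swap at one position shows little about the chain as a whole, and it remains open whether an amine, a carboxylic acid or a longer chain at this position would give a step beyond the scatter. Going by these compounds, it also remains open whether the same methoxy swap would behave in the same way on the core of compound 2.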